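Swapping the amide end on a shared core

This account rests on a few compounds, and the source may have more. Where it says the series, first, only, none or still open, it means among the compounds named here.

Compound 1 `CCCCNC(=O)COc1ccc(C(=O)c2c(CCCC)oc3ccccc23)cc1`: 22800 nM
Compound 2 `CCCCc1oc2ccccc2c1C(=O)c1ccc(OCC(=O)N2CCOCC2)cc1`: 45400 nM
Compound 3 `CCCCc1oc2ccccc2c1C(=O)c1ccc(OCC(=O)N[C@@H](C)c2ccccc2)cc1`: 33800 nM

All three values come from a functional assay on U-937 cells (Homo sapiens) for antiproliferative activity, read by MTT assay, with a stated time of 24 h (a lower number here means a stronger inhibitor, a higher number a weaker inhibitor), and they form one tight cluster. Compound 3 stands inside that cluster, not apart from either of the others. The gaps around it are a 1.5-fold higher number from compound 1 to compound 3 (0.17 log units; within the scatter) and a 1.3-fold lower number from compound 2 to compound 3 (0.13 log units; within the scatter).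

The next compound is compound 4 `CCCCNC(=O)CCCOc1ccc(C(=O)c2c(CCCC)oc3ccccc23)cc1`, and the change is 2-(butylcarbamoyl)ethyl in place of (1-phenylethyl)carbamoyl on a saturated chain carbon bound to an oxygen on an aromatic ring. Part of this change has a measured precedent, since the butyl group on the amide nitrogen also occurs in compound 1, and that exchange gave a 1.5-fold higher number from compound 1 to compound 3 (0.17 log units; within the scatter). A different change at the amide end gave a 2.0-fold higher number from compound 1 to compound 2 (0.30 log units; within the scatter). Within the data shown here, no measured compound carries the 2-(butylcarbamoyl)ethyl group, so the data do not cover that part of the change. No step beyond the scatter is therefore expected. The estimated step is a 1.2-fold lower number from compound 3 to compound 4 (0.08 log units; within the scatter). For compound 4 the estimated value is 28000 nM, with an expected range from 12000 nM to 60000 nM.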

Compound 4, half-maximal inhibitory concentration: 24600 nM
Compound 4: middle estimate off by 1.1-fold (0.06 log units), on the high side; the range from low to high includes it.
By their numbers in this assay, from the lowest: compounds 1, 4, 3 and 2 (each within the scatter of the next).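

In this assay, among these compounds, the chain bearing the amide changes for the first time, while the butyl group on the amide nitrogen stays the same: 2-(butylcarbamoyl)ethyl in place of butylcarbamoyl leaves the number within the scatter (a 1.1-fold higher number from compound 1 to compound 4 (0.03 log units; within the scatter)). The same group also stays within the scatter when it enters in place of (1-phenylethyl)carbamoyl (a 1.4-fold lower number from compound 3 to compound 4 (0.14 log units; within the scatter)) or (morpholin-4-yl)carbonyl (a 1.8-fold lower number from compound 2 to compound 4 (0.27 log units; within the scatter)), so this position has so far tolerated changes to both the chain and the amide end, and all four compounds form one cluster. Nothing measured here accounts for these values.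

As far as these compounds go, it remains open whether a longer chain, or a carboxylic acid or an amine in place of the amide, would give a step beyond the scatter. From the compounds shown here alone, it is also open whether the morpholin-4-yl and 1-phenylethyl amide ends would behave the same way on the 2-(butylcarbamoyl)ethyl chain.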